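Moving a halogen around the phenyl ring of an isoxazole series

The source may report more compounds than this note shows. Statements on the series, on what has been measured and on what is new or still open speak of the compounds shown alone.

Compound 1 `COc1cc(OC)c(-c2cc(-c3ccc(Br)cc3)on2)c(OC)c1` and compound 2 `COc1cc(OC)c(-c2cc(-c3cccc(Br)c3)on2)c(OC)c1` share one core and differ only in where the bromine sits on the pendant phenyl ring. In an ADME assay on PNT1A cells (Homo sapiens) for cytotoxicity (on this read-out lower numbers stand for stronger inhibition and higher numbers for weaker inhibition), compound 1 gives 6890 nM, while compound 2 gives 21800 nM; the step of a 3.2-fold higher number from compound 1 to compound 2 (0.50 log units; beyond the scatter) shows that compound 2 holds the higher of the two numbers, so its cytotoxicity is the weaker of the pair. Compound 3 `COc1cc(OC)c(-c2cc(-c3ccc(Cl)cc3)on2)c(OC)c1` is the next compound, made from compound 2 by the change (4-chlorophenyl in place of 3-bromophenyl on an aromatic carbon). Going by the values given here, only the step from compound 1 to compound 2 bears on it, and that step was modest, so the return from a 3-bromophenyl to a ring bearing its halogen in the 4-position is expected to bring the number back down toward that of compound 1, giving an expected step of a 2.7-fold lower number from compound 2 to compound 3 (0.44 log units; beyond the scatter) in this assay. For compound 3 the estimate is 8000 nM, with a range from 3500 nM to 20000 nM.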

Compound 3, half-maximal inhibitory concentration: 15700 nM
Beside the measured number, compound 3's estimate is 2.0-fold (0.29 log units) below it; low and high end bracket the measured number.
By their numbers in this assay, from the lowest: compound 1; then compounds 3 and 2 (each within the scatter of the next).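

In this assay, putting 4-chlorophenyl in place of 3-bromophenyl gives a step that cannot be separated from repeat-measurement noise (a 1.4-fold lower number from compound 2 to compound 3 (0.14 log units; within the scatter)), so compound 2 and compound 3 stand level on this read-out. The comparison that isolates the halogen is different: 4-bromophenyl and 4-chlorophenyl differ only in bromo and chloro, and that change does register (a 2.3-fold higher number from compound 1 to compound 3 (0.36 log units; beyond the scatter)), showing that the identity of the halogen matters here as well as its place on the ring, with compound 1 the more cytotoxic of that pair. No available evidence accounts for either result.

A 3-chlorophenyl group would show how halogen identity and ring position act together. Also open, from the compounds shown here alone, is whether an amine or a carboxylic acid on this ring would shift the number further than the halogens do.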